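Benzyl on the ring nitrogen: a change without a measured precedent

The source may report more compounds than this note shows. Statements on the series, on what has been measured and on what is new or still open speak of the compounds shown alone.

Compound 1 `CCOC(=O)/C=C1/C(=O)Nc2ccccc21` and compound 2 `CC(C)(C)OC(=O)/C=C1/C(=O)Nc2ccccc21` share one core and differ only in the ester group. In a toxicity assay on L02 cells (Homo sapiens) for inhibition, read by CCK-8 assay, with a stated time of 72 h, tested at 20 uM (on this read-out lower numbers stand for less inhibition of growth and higher numbers for more inhibition of growth at the one concentration tested), compound 1 gives 63.9%, and in this assay compound 2 gives 64.1%. Within the data shown here, the one measured step, a number 0.2 percentage points higher from compound 1 to compound 2 (within the scatter), lies within the scatter, so compound 2 stands alongside compound 1 with no difference that can be trusted. Compound 3 `CC(C)(C)OC(=O)/C=C1/C(=O)N(Cc2ccccc2)c2ccccc21` is not yet measured; it differs from compound 2 by benzyl in place of hydrogen on an amide-type nitrogen in a ring. Among the measured compounds shown here, no measured step touches this position, so the ester step gives no direct guide, and the only sign is that one change elsewhere left the number unmoved. The expectation for compound 3 is therefore a step of a number 2.1 percentage points lower from compound 2 to compound 3 (within the scatter), none beyond the scatter. Compound 3 is estimated at 62%, between 46% and 78%.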

Compound 3, percent growth inhibition at one concentration: 62%
Compound 3: middle estimate and measured number agree at the digits printed; measured number inside the range.
By their numbers in this assay, from the lowest: compounds 3, 1 and 2 (each within the scatter of the next).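

Among these compounds, this is the first measured change on the ring nitrogen: in this assay, benzyl in place of hydrogen on an amide-type nitrogen in a ring gives a number 2.1 percentage points lower from compound 2 to compound 3 (within the scatter). The amide hydrogen is therefore not required for this level of growth inhibition at the one concentration tested, and the nitrogen can carry benzyl with no difference that can be trusted. Nothing measured here bears on the reason for this result.

The compounds shown leave open whether another group on this nitrogen, such as methyl, a longer carbon chain, or a chain ending in an amine or a carboxylic acid, would also leave the number in place. They also leave open whether benzyl on the nitrogen would give the same result alongside the ethyl ester of compound 1.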